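The source may hold more compounds than are shown below. What is called first, only, known or untested is meant among the compounds shown, and "the series" means these compounds.

Working notes on the series. The shared core carries a chloro-substituted phenoxyacetic acid joined through an alkyne to a second aromatic ring; the compounds differ in what sits on that second ring. Among the compounds with values here, compound 1 `CC(C)Cc1ccncc1C#Cc1cc(Cl)ccc1OCC(=O)O` and compound 2 `Cc1ccc(S(=O)(=O)N2CCN(C)CC2)cc1C#Cc1cc(Cl)ccc1OCC(=O)O` are the two measured members. In an assay on CHO cells for displacement of a labelled ligand from prostaglandin D2 receptor 2 (Homo sapiens), read by scintillation counting (a lower number here means a stronger inhibitor, a higher number a weaker inhibitor), compound 1 gives 4.9 nM, while compound 2 gives 21 nM in this assay, the higher of the two numbers, and the gap between them lies beyond the usual scatter. Compound 2 thus stands as the weaker of the two measured binders.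

Compound 3 `Cc1ccc(S(=O)(=O)N(C)C(C)C)cc1C#Cc1cc(Cl)ccc1OCC(=O)O` is the next member to be measured. It differs from compound 2 in one place: isopropyl(methyl)amino in place of 4-methylpiperazin-1-yl on a sulfonyl sulfur. Within the data shown here, no measured pair shows this change, so no step is known for it. The expectation is that the change from compound 2 to compound 3 produces no step beyond the scatter in this assay, in either direction, the step being estimated as a 1.4-fold lower number from compound 2 to compound 3 (0.15 log units; within the scatter). On that basis compound 3 is expected to give about 15 nM in this assay, with a range from 5 nM to 50 nM.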

Compound 3, inhibition constant: 3.8 nM
Compound 3: middle estimate off by 3.9-fold (0.60 log units), on the high side; measured number outside the range, below it.
By their numbers in this assay, from the lowest: compounds 3 and 1 (each within the scatter of the next); then compound 2.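

In this assay, the group on the sulfonyl sulfur whose other neighbour is an aromatic carbon is not a silent place in the series: isopropyl(methyl)amino in place of 4-methylpiperazin-1-yl gives a 5.5-fold lower number from compound 2 to compound 3 (0.74 log units; beyond the scatter). Within the data shown here, this is the first step that can be read, and it shows that the six-membered non-aromatic ring and the second nitrogen of 4-methylpiperazin-1-yl are not needed for a low number on this scaffold, as the open-chain group with fewer heavy atoms does better than the ring. No measurement on hand accounts for the size or the direction of this step, which therefore stands as an observation only.

The change removes the ring and the second nitrogen together, so the compounds shown leave open which of the two goes with the step. A piperidin-1-yl or morpholin-4-yl group on the same sulfonyl sulfur would keep the ring while replacing that nitrogen, and a diethylamino or dimethylamino group would show how far the open-chain amine can be varied.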